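The source may hold more compounds than are shown below. What is called first, only, known or untested is meant among the compounds shown, and "the series" means these compounds.

Working notes on the series. Three compounds share a core and differ in one group at a time; a fourth remains to be measured. In a functional assay on A2780 cells (Homo sapiens) for inhibition, read by sulforhodamine B assay (a lower number here means a stronger inhibitor of growth, a higher number a weaker inhibitor of growth), compound 1 `Oc1cccc2[nH]c(-c3ccc(-c4ccc(-c5ccc(C(F)(F)F)cc5)cc4)cc3)nc12` gives 6100 nM. Compound 2 `Oc1cccc2[nH]c(-c3ccc(-c4ccc(-c5ccc(OC(F)(F)F)cc5)cc4)cc3)nc12` differs from compound 1 by trifluoromethoxy in place of trifluoromethyl on an aromatic carbon and in this assay compound 2 gives 2900 nM, the step being a 2.1-fold lower number from compound 1 to compound 2 (0.32 log units; beyond the scatter). Compound 3 `Cc1ccc2[nH]c(-c3ccc(-c4ccc(-c5ccc(C(F)(F)F)cc5)cc4)cc3)nc2c1` carries a different core; the difference between the two cores is 5-methyl-1H-benzimidazol-2-yl in place of 4-hydroxy-1H-benzimidazol-2-yl on an aromatic carbon, and in this assay compound 3 gives 12300 nM, a step of a 2.0-fold higher number from compound 1 to compound 3 (0.30 log units; within the scatter). Compound 4 `Cc1ccc2[nH]c(-c3ccc(-c4ccc(-c5ccc(OC(F)(F)F)cc5)cc4)cc3)nc2c1` has not yet been measured. It differs from compound 3 by trifluoromethoxy in place of trifluoromethyl on an aromatic carbon. This is the same change as that from compound 1 to compound 2, now made on the core of compound 3, and the surroundings of the changed group read the same in both pairs. Among these compounds the change occurs twice, once with a measured result. Among the compounds with values here, for compound 4 in this assay a step of about a 2.1-fold lower number from compound 3 to compound 4 (0.31 log units; beyond the scatter) is expected, because a 2.1-fold lower number from compound 1 to compound 2 (0.32 log units; beyond the scatter) is the only measured instance of this change. Whether the core of compound 3 alters the size of that step is not shown by anything here. Compound 4 is therefore estimated at 6000 nM, expected to fall between 2500 nM and 14000 nM. With a single precedent the range is kept wide.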

Compound 4, concentration for 50% growth inhibition: 12300 nM
Estimate against measurement, compound 4: 2.1-fold (0.31 log units) below, and the stated range covers the measured number.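

In this assay, trifluoromethoxy in place of trifluoromethyl on the core of compound 3 gives no change at the digits printed from compound 3 to compound 4 (within the scatter), and this step does not differ measurably from its earlier instance: the same change on two cores in this assay, a 2.1-fold lower number (0.32 log units; beyond the scatter) from compound 1 to compound 2 and no change at the digits printed (within the scatter) from compound 3 to compound 4, 2.1-fold (0.32 log units) apart, within the scatter of two such steps

The change of core, read with trifluoromethoxy in place, gives a 4.2-fold higher number from compound 2 to compound 4 (0.63 log units; beyond the scatter), and this step likewise does not differ measurably from the same core change read with trifluoromethyl: the same change on two cores in this assay, a 2.0-fold higher number (0.30 log units; within the scatter) from compound 1 to compound 3 and a 4.2-fold higher number (0.63 log units; beyond the scatter) from compound 2 to compound 4, 2.1-fold (0.32 log units) apart, within the scatter of two such steps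

These two comparisons are consistent with carrying the change from one core to the other, but with one pair on each core they neither establish that the step is constant nor show that the core alters it.

Open, from the compounds shown here alone, is how the step would behave with other groups on the same aromatic carbon, such as an amine or a carboxylic acid, and on cores other than these two. Going by these compounds, all four readings come from this assay, so whether the same comparisons hold in any other test remains unknown.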